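Bromo to fluoro on the core of compound 1

A few compounds are considered here, and "the series" means these few. Any claim that something is new, unique, unknown or untested is made for them only; others in the source may bear on it.

Going by the values given here, in a functional assay on KYSE-410 cells (Homo sapiens) for antiproliferative activity, read by MTT assay, with a stated time of 72 h (on this read-out lower numbers stand for stronger inhibition and higher numbers for weaker inhibition), compound 1 (`O=C(Nc1cccc(F)c1)c1cc(=O)[nH]c2cc(Br)ccc12`) gives 7300 nM as the only actual number so far. Compound 2 (`COc1cccc(NC(=O)c2cc(=O)[nH]c3cc(Br)ccc23)c1`) reads > 20000 nM in this assay and this is a limit of the assay, not a number. Among the compounds with values here, the single measured step (an at least 2.7-fold higher number from compound 1 to compound 2 (0.43 log units; beyond the scatter)) is methoxy in place of fluoro on an aromatic carbon and is no more than a bound. Compound 3 (`O=C(Nc1cccc(F)c1)c1cc(=O)[nH]c2cc(F)ccc12`) has fluoro in place of bromo on an aromatic carbon of the shared core. Within the data shown here, no measured step covers this change, so that bound offers only weak guidance, and a small move to a higher number in this assay is expected, perhaps not beyond the scatter. The expected change (a 1.5-fold higher number from compound 1 to compound 3 (0.18 log units; within the scatter)) is an estimate only. Compound 3 is estimated at 11000 nM with an expected range of 4000 nM to 25000 nM in this series.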

Compound 3, half-maximal inhibitory concentration: > 20000 nM
Compound 3 ended at the assay's limit (the forecaster's own chance of this, stated with the estimate: 30%); middle value at least 1.8-fold (0.25 log units) from the limit.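

In this assay, this carbon of the shared core proves sensitive to the change of halogen: fluoro in place of bromo gives an at least 2.7-fold higher number from compound 1 to compound 3 (0.43 log units; beyond the scatter). Going by these compounds, compound 3 reads > 20000 nM, which is a limit of the assay and not a number, so this step is a bound and its full size stays unknown. The earlier step changed a different place, so this is the first sign that the core bromo also counts, and both single changes from compound 1 now end at the same ceiling: the limit of > 20000 nM in this assay, at which 2 of the 3 values shown sit.

On these data alone, whether bromo is specifically needed on this carbon stays open, as does whether any group here can give a lower number than compound 1. Chloro, iodo, methyl or an amine at this carbon would begin to answer both questions.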